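Pyridin-3-yl for 4-Chlorophenyl: Expected Effect on Topoisomerase 1

A few compounds are considered here, and "the series" means these few. Any claim that something is new, unique, unknown or untested is made for them only; others in the source may bear on it.

Compound 1 `Clc1ccc(-c2cc(-c3ccoc3)cc(-c3ccc(Cl)s3)n2)cc1` and compound 2 `Clc1ccc(-c2cc(-c3ccoc3)cc(-c3cccnc3)n2)s1` differ in a single place. In an assay on isolated protein for inhibition of DNA topoisomerase 1 (Homo sapiens), with a stated time of 30 min, tested at 100 uM (on this read-out lower numbers stand for less inhibition and higher numbers for more inhibition at the one concentration tested (going by the name of the read-out)), compound 1 gives 2.3%. In this assay compound 2 gives 2%. The change between them is pyridin-3-yl in place of 4-chlorophenyl on an aromatic carbon, and it made a number 0.3 percentage points lower from compound 1 to compound 2 (within the scatter).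

Compound 3 `Cc1ccsc1-c1cc(-c2ccc(Cl)o2)cc(-c2ccc(Cl)cc2)n1` is built on a different core; how its core differs from that of compound 1 is not broken down here. In this assay compound 3 gives 5.1%.

Compound 4 `Cc1ccsc1-c1cc(-c2ccc(Cl)o2)cc(-c2cccnc2)n1` has not been measured. It arises from compound 3 by pyridin-3-yl in place of 4-chlorophenyl on an aromatic carbon. Going by the values given here, this is the same kind of change as the one from compound 1 to compound 2, but not the same one: in compound 3 the place is meta to a 3-methylthiophen-2-yl group and meta to a 5-chlorofuran-2-yl group, whereas in compound 1 it is meta to a 5-chlorothiophen-2-yl group and meta to a furan-3-yl group. Because the earlier change made a number 0.3 percentage points lower from compound 1 to compound 2 (within the scatter), a step of similar, small size is expected here: a number 0.1 percentage points lower from compound 3 to compound 4 (within the scatter). Compound 4 is therefore estimated at 5% in this assay, most likely between 0% and 12%.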

Compound 4, a percentage reported as inhibition, at one concentration (the size of the read-out at that concentration, not a potency): 21.4%
For compound 4 the middle estimate is 16.4 percentage points below the measured one; the whole stated range lies below it.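

On the core of compound 3, pyridin-3-yl in place of 4-chlorophenyl made a number 16.3 percentage points higher from compound 3 to compound 4 (beyond the scatter) in this assay. Set beside the earlier pair, the same change did not carry over from one core to the other with the same size: the same change on two cores in this assay, a number 0.3 percentage points lower (within the scatter) from compound 1 to compound 2 and a number 16.3 percentage points higher (beyond the scatter) from compound 3 to compound 4, 16.6 percentage points apart, beyond the scatter of two such steps So in this series the outcome of the swap cannot simply be copied from one core to another, yet two pairs give no general rule for other cores, and each reading is the size of the effect at one concentration, not a potency.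

The compounds shown leave open which of the differences between the two cores matters, such as 3-methylthiophen-2-yl against 5-chlorothiophen-2-yl or 5-chlorofuran-2-yl against furan-3-yl, since these groups do not vary one at a time here. They also leave open how other groups at this place would read, such as an unsubstituted phenyl, pyridin-4-yl, or a ring carrying an amine or a carboxylic acid.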